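Replacing Ethoxy with Fluoro in a Small Series

The source may hold more compounds than are shown below. What is called first, only, known or untested is meant among the compounds shown, and "the series" means these compounds.

Measured in a functional assay on SGC-7901 cells (Homo sapiens) for antiproliferative activity, read by MTT assay, with a stated time of 48 h; on this read-out higher numbers stand for weaker inhibition and lower numbers for stronger inhibition:
Compound 1 `COc1ccccc1-c1nnc(SCc2ccc(Cl)nc2)o1`: 8.2 ug/mL
Compound 2 `CCOc1ccccc1-c1nnc(SCc2ccc(Cl)nc2)o1`: 10.3 ug/mL

For the measured compounds named here, compound 2, at 10.3 ug/mL, cannot be separated from the only other measured compound. The step between them is a 1.3-fold higher number from compound 1 to compound 2 (0.10 log units; within the scatter). The next compound keeps the shared core but changes the same substituent more drastically. Compound 3 `Fc1ccccc1-c1nnc(SCc2ccc(Cl)nc2)o1` has fluoro in place of ethoxy on an aromatic carbon, ortho to a large group: fluoro in place of ethoxy on an aromatic carbon.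

Going by the values given here, only one measured step bears on this swap, and it is an imperfect guide. In it, methyl replaces hydrogen on the saturated chain carbon bound to oxygen, so the chain changes but the oxygen stays. Among the compounds with values here, no measured compound shows what happens when that oxygen and its chain are removed altogether. The step of a 1.3-fold higher number from compound 1 to compound 2 (0.10 log units; within the scatter) gives no reason to expect a large shift, yet it cannot exclude one, so the range must stay wide. In this assay, the expected change is no larger than the scatter, and its direction is uncertain: a 1.1-fold lower number from compound 2 to compound 3 (0.06 log units; within the scatter). The estimated value for compound 3 is 9 ug/mL. The expected range for compound 3 runs from 3.5 ug/mL to 22 ug/mL.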

Compound 3, half-maximal inhibitory concentration: 9.12 ug/mL
Beside the measured number, compound 3's estimate is 1.0-fold (0.01 log units) below it, within the range that was stated.
By their numbers in this assay, from the lowest: compounds 1, 3 and 2 (each within the scatter of the next).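

In this assay, for the compounds shown here, the earlier compounds only showed a change within the chain, with the oxygen kept on the aromatic carbon, whereas this swap removes both the oxygen and the chain, leaving fluoro, a single heavy atom, in place of the three heavy atoms of ethoxy, and the result is a 1.1-fold lower number from compound 2 to compound 3 (0.05 log units; within the scatter). Set against the methoxy group the picture is the same, with a 1.1-fold higher number from compound 1 to compound 3 (0.05 log units; within the scatter), so among these three compounds, an oxygen-linked chain on this aromatic carbon is not needed for a number in this range, and neither swap can be told apart from repeat-measurement noise. Nothing measured here offers an explanation for this flat result, so the reason for it remains unknown.

Going by these compounds, whether an amine, a carboxylic acid or a longer chain such as butoxy on this same carbon would stay this close or would move the number beyond the scatter remains open. On these data alone, all three compounds also share the rest of the structure, so it is equally open whether changes elsewhere on the shared core would matter more than this one.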